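Chloro to Amino on the Fused Ring: What to Expect

This account rests on a few compounds, and the source may have more. Where it says the series, first, only, none or still open, it means among the compounds named here.

Compound 1 `Nc1nn(C(=O)Nc2ccc(Cc3ccccc3)cc2)c2ccccc12` and compound 2 `Nc1nn(C(=O)Nc2ccc(Cc3ccccc3)cc2)c2ccc(Cl)cc12` share one core and differ only by a chloro on an aromatic carbon. In a functional assay on Malme-3M cells (Homo sapiens) for antiproliferative activity, read by sulforhodamine B assay, with a stated time of 48 h (a higher number here means a weaker inhibitor of growth, a lower number a stronger inhibitor of growth), compound 1 gives 19200 nM. In this assay compound 2 gives 6690 nM. For the measured compounds named here, the step of a 2.9-fold lower number from compound 1 to compound 2 (0.46 log units; beyond the scatter) is modest yet beyond the scatter, so compound 2 holds the lowest of the two numbers known, with compound 1 as its only neighbour.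

Compound 3 `Nc1ccc2c(c1)c(N)nn2C(=O)Nc1ccc(Cc2ccccc2)cc1` is made from compound 2 by amino in place of chloro on an aromatic carbon. Going by the values given here, the only measured step touching this place, a 2.9-fold lower number from compound 1 to compound 2 (0.46 log units; beyond the scatter), concerns chloro against hydrogen and says nothing direct about amino; it shows only that this position can shift the number. With no measured guide for amino, a small rise toward the value of compound 1 seems the most reasonable expectation, held with wide uncertainty. Compound 3 is therefore expected near 12000 nM, within 4000 nM to 40000 nM, an estimated step of a 1.8-fold higher number from compound 2 to compound 3 (0.25 log units; within the scatter).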

Compound 3, concentration for 50% growth inhibition: 18000 nM
Compound 3: the middle estimate sits 1.5-fold (0.18 log units) below what was measured; the range from low to high includes it.
By their numbers in this assay, from the lowest: compound 2; then compounds 3 and 1 (each within the scatter of the next).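

Amino in place of chloro gives a 2.7-fold higher number from compound 2 to compound 3 (0.43 log units; beyond the scatter) in this assay, so the gain seen with chloro does not carry over to amino. Set against hydrogen, amino gives a 1.1-fold lower number from compound 1 to compound 3 (0.03 log units; within the scatter), which means compound 3 and compound 1 cannot be told apart here. The position therefore does not shift the number with every group placed on it: of the two groups shown on this aromatic carbon, only chloro separates from hydrogen by more than the scatter.

Three compounds cannot show whether the lower number of compound 2 belongs to chloro alone or would also appear with fluoro, bromo, methoxy or a nitrile. Nothing available explains why chloro and amino part ways at this position.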